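Chain extension from compound 3 to compound 4

This account rests on a few compounds, and the source may have more. Where it says the series, first, only, none or still open, it means among the compounds named here.

Values in a functional assay on MDA-MB-231 cells (Homo sapiens) for inhibition, read by MTT assay, with stated times of 18 h and 4 h; on this read-out higher numbers stand for weaker inhibition and lower numbers for stronger inhibition:
- compound 1 `CCCOP(=O)(O)OCCSC(=S)N1CCCCC1`: 68000 nM
- compound 2 `CCCCCCCCCCOP(=O)(O)OCCSC(=S)N1CCN(C)CC1`: 29000 nM
- compound 3 `CCCOP(=O)(O)OCCSC(=S)N1CCCC1`: 67000 nM

Compound 3 stands at the high end of these numbers, within the scatter of compound 1 and beyond the scatter from compound 2. The change to compound 4 `CCCCCCOP(=O)(O)OCCSC(=S)N1CCCC1` is propyl in place of hydrogen on a saturated chain carbon, three bonds along the chain from an oxygen on an unsaturated carbon, which reads as propyl to hexyl. Going by the values given here, the one measured step, a 1.0-fold lower number from compound 1 to compound 3 (0.01 log units; within the scatter), concerns the amine ring and not the chain, so it gives no size for this change. Among the compounds with values here, no measured step isolates chain length. Compound 2, with its decyl chain and a different amine ring, gives 29000 nM, the only weak hint of a lower number. On that basis, the expected change in this assay is modest: a 1.5-fold lower number from compound 3 to compound 4 (0.17 log units; within the scatter). For compound 4 the estimated value is 45000 nM, with an expected range of 22000 nM to 80000 nM.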

Compound 4, half-maximal inhibitory concentration: 54000 nM
Compound 4: middle estimate off by 1.2-fold (0.08 log units), on the low side; measured number inside the range.
By their numbers in this assay, from the lowest: compounds 2, 4, 3 and 1 (each within the scatter of the next, the first and the last beyond it).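

In this assay, going by these compounds alone, the step of a 1.2-fold lower number from compound 3 to compound 4 (0.09 log units; within the scatter) gives the first direct reading of chain length, and it lies within the scatter. Propyl in place of hydrogen at this saturated chain carbon therefore produces no resolved shift at the hexyl length. No available evidence bears on this result.

Still open, as far as these compounds go, is whether a longer chain, such as octyl or dodecyl, on the core of compound 4 would give a step beyond the scatter. From the compounds shown here alone, the effect of a morpholine ring in place of the pyrrolidin-1-yl group at hexyl length is also open.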